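The source may report more compounds than this note shows. Statements on the series, on what has been measured and on what is new or still open speak of the compounds shown alone.

Measured compounds:
compound 1 `CCOc1cccc(-c2ccc(CN(C(=O)C3CCCCC3)c3cccc(/C=C/C(=O)OC)c3)cc2)c1` — 147 nM
compound 2 `CCOc1cccc(-c2ccc(CN(C(=O)C(C)C)c3cccc(/C=C/C(=O)OC)c3)cc2)c1` — 173 nM
compound 3 `COC(=O)/C=C/c1cccc(N(Cc2ccc(/C=C/C(=O)OC(C)(C)C)cc2OS(C)(=O)=O)C(=O)C2CCCCC2)c1` — > 1000 nM

In an assay on isolated protein with Bile acid receptor (Homo sapiens) as the target (on this read-out lower numbers stand for an effect already at smaller amounts and higher numbers for an effect only at larger amounts of compound), compound 1 gives 147 nM, the lowest of the two numbers reported as numbers. Compound 2 sits close by: the step of a 1.2-fold higher number from compound 1 to compound 2 (0.07 log units; within the scatter) does not separate the two, so the cyclohexyl and isopropyl amides read the same within this assay. Compound 3 is reported only as a limit of the assay, > 1000 nM, and not as a number; it marks (the limit of > 1000 nM in this assay, at which 1 of the 3 values shown sits). Among the compounds with values here, no single-point step joins compound 3 to compound 1, so its value shows only that the compound sits at the limit.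

The unmeasured compound 4 `COC(=O)/C=C/c1cccc(N(Cc2ccc(-c3cccc(C(C)=O)c3)cc2)C(=O)C2CCCCC2)c1` differs from compound 1 in one place: acetyl in place of ethoxy on an aromatic carbon. Within the data shown here, no measured step touches the aryl group carrying the ethoxy; the one step known, from cyclohexyl to isopropyl on the carbonyl carbon, was within the scatter and says nothing about this position. The change keeps the same count of heavy atoms and acceptors, so the expectation rests on the size of the group alone.

For compound 4 the number in this assay is expected at 250 nM, with a range of 100 nM to 700 nM. This estimate means a step of a 1.7-fold higher number from compound 1 to compound 4 (0.23 log units; within the scatter), expected to fall close to the scatter rather than clearly beyond it.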

Compound 4, half-maximal effective concentration: 227 nM
Estimate against measurement, compound 4: 1.1-fold (0.04 log units) above; the measured number falls inside the stated range.
By their numbers in this assay, from the lowest: compounds 1, 2 and 4 (each within the scatter of the next). At a limit, above all of these: compound 3.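

The change from 3-ethoxyphenyl to 3-acetylphenyl is the only step shown at this position, and in this assay it gives a 1.5-fold higher number from compound 1 to compound 4 (0.19 log units; within the scatter). On an aromatic carbon meta to a large group, ethoxy and acetyl therefore read the same in this assay, even though acetyl brings a double bond outside aromatic rings that ethoxy does not have, so this position is not shown to separate these two groups of equal heavy-atom and hydrogen-bond-acceptor count. No measurement on hand bears on why the two groups read the same.

Still open, on these data alone, is how this position responds to groups further removed from these two, such as a carboxylic acid, an amine or a longer alkoxy chain in place of ethoxy, any of which might or might not step beyond the scatter. Also open, as far as these compounds go, is whether the match between ethoxy and acetyl, seen here only with cyclohexyl on the amide carbonyl, carries over to the isopropyl amide of compound 2.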